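Swapping the aryl group on the isoxazoline: compound 4

This account rests on a few compounds, and the source may have more. Where it says the series, first, only, none or still open, it means among the compounds named here.

Measured so far:
Compound 1 `COc1cc(-n2nnnc2-c2ccc(OCC3CC(c4cccc(Cl)c4)=NO3)c(N)c2)cc(OC)c1OC` — 2180 nM
Compound 2 `COc1cc(-n2nnnc2-c2ccc(OCC3CC(c4ccc(C(F)(F)F)cc4)=NO3)c(N)c2)cc(OC)c1OC` — 1750 nM
Compound 3 `COc1ccc(F)c(C2=NOC(COc3ccc(-c4nnnn4-c4cc(OC)c(OC)c(OC)c4)cc3N)C2)c1` — 2830 nM

These three compounds share one core and differ only in the aryl group on a carbon with a double bond to nitrogen. In a functional assay on MDA-MB-231 cells (Homo sapiens) for cytotoxicity, read by MTT assay, with a stated time of 48 h (on this read-out lower numbers stand for stronger inhibition and higher numbers for weaker inhibition), compound 1 gives 2180 nM, the second highest of the three numbers; its nearest neighbour is compound 2 and its furthest is compound 3, and both lie within the scatter of it.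

Compound 4 `COc1ccc(C2=NOC(COc3ccc(-c4nnnn4-c4cc(OC)c(OC)c(OC)c4)cc3N)C2)cc1OC` differs from compound 1 in one place: 3,4-dimethoxyphenyl in place of 3-chlorophenyl on a carbon with a double bond to nitrogen.

All three measured steps bear on this change, since each also swaps the aryl group at that same position: a 1.2-fold lower number from compound 1 to compound 2 (0.10 log units; within the scatter), a 1.3-fold higher number from compound 1 to compound 3 (0.11 log units; within the scatter) and a 1.6-fold higher number from compound 2 to compound 3 (0.21 log units; within the scatter). None of them reaches beyond the scatter. So far the read-out of this assay has not been moved by which aryl group sits there, and the step to compound 4 is therefore expected to stay within the scatter as well, with no clear direction: a 1.1-fold higher number from compound 1 to compound 4 (0.04 log units; within the scatter).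

For compound 4 the expected value in this assay is 2400 nM, in an estimated range from 1200 nM to 4800 nM.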

Compound 4, half-maximal inhibitory concentration: 3570 nM
Estimate against measurement, compound 4: 1.5-fold (0.17 log units) below; measured number inside the range.
By their numbers in this assay, from the lowest: compounds 2, 1, 3 and 4 (each within the scatter of the next, the first and the last beyond it).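

In this assay, among the compounds shown here, the swap to 3,4-dimethoxyphenyl yields the only step at this position that passes the usual scatter, a 2.0-fold higher number from compound 2 to compound 4 (0.31 log units; beyond the scatter), though the step is modest and holds only against the 4-(trifluoromethyl)phenyl group of compound 2. The other two new steps, a 1.6-fold higher number from compound 1 to compound 4 (0.21 log units; within the scatter) and a 1.3-fold higher number from compound 3 to compound 4 (0.10 log units; within the scatter), stay within the scatter, so the aryl group on this carbon with a double bond to nitrogen can shift the number slightly, but only the two ends of the series can be told apart. Nothing measured here offers a reason for that one modest difference.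

On these data alone, all four compounds carry a substituted phenyl group at this position, so it remains open what a group without an aromatic ring, such as a longer alkyl chain, an amine or a carboxylic acid, would do on this carbon. Every difference shown also lies at this one position, which leaves open how changes elsewhere on the shared core would affect the number.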